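The compounds below may be only part of what the source reports. "The series", "measured", "known", "first", "only" and "open" are said of these compounds alone.

Compound 1 `Cc1cc(C(=O)O)nn1Cc1cc(Br)ccc1OCc1cccc(Br)c1`: 129 nM
Compound 2 `Cc1cc(C(=O)O)nn1Cc1cc(Br)ccc1OCc1cccc([N+](=O)[O-])c1`: 339 nM

Going by the values given here, in a functional assay on CHO-K1 cells for antagonist activity at prostaglandin E2 receptor EP1 subtype (Homo sapiens), read by FLIPR (on this read-out lower numbers stand for stronger inhibition and higher numbers for weaker inhibition), compound 2 gives 339 nM, the higher of the two numbers so far, while compound 1 gives 129 nM. Among the compounds with values here, the single step known between them, a 2.6-fold higher number from compound 1 to compound 2 (0.42 log units; beyond the scatter), shows that swapping bromo for nitro on the outer ring weakened inhibition by a modest but real amount.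

Compound 3 `Cc1cc(C(=O)O)nn1Cc1cc(Br)ccc1OCc1cccc(C(F)(F)F)c1` differs from compound 2 by trifluoromethyl in place of nitro on an aromatic carbon. Within the data shown here, no measured pair tells what trifluoromethyl does at that position, so the only guide is that one step, which says the nitro compound sits at the weaker end of the two. Compound 3 is therefore expected to return part of the way toward the bromo compound, an estimated step of a 1.8-fold lower number from compound 2 to compound 3 (0.25 log units; within the scatter). Compound 3 is estimated at 190 nM, within a range from 80 nM to 450 nM.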

Compound 3, inhibition constant: 1100 nM
For compound 3 the middle estimate is 5.8-fold (0.76 log units) below the measured one; measured number above the stated range.
By their numbers in this assay, from the lowest: compound 1; then compound 2; then compound 3.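

Trifluoromethyl turns out to be the poorest of the three groups at this aromatic carbon: a 3.2-fold higher number from compound 2 to compound 3 (0.51 log units; beyond the scatter), and an 8.5-fold higher number from compound 1 to compound 3 (0.93 log units; beyond the scatter). So this position does more than separate bromo from nitro, since the three groups now fall into a clear order, with compound 1 the strongest inhibitor and compound 3 the weakest, and replacing one small group without a ring by another can cost real inhibition. No supporting measurement is available to explain why trifluoromethyl does worse than either of the other groups.

From the compounds shown here alone, three groups cannot show which feature of a group sets this order, so it remains open where a chloro group, a methyl group, an amine or a longer chain would fall. It is also unknown whether the same order would hold if the group sat on another carbon of that ring.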